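This account rests on a few compounds, and the source may have more. Where it says the series, first, only, none or still open, it means among the compounds named here.

Measured compounds:
- compound 1 `CCOC(=O)c1[nH]c(=O)c(C#N)cc1C(=O)c1ccccc1`: 465000 nM
- compound 2 `CCOC(=O)c1[nH]c(=O)c(C#N)cc1C(=O)c1ccc(Cl)cc1`: 218000 nM

In an ADME assay on L929 cells (Mus musculus) for cytotoxicity, read by MTT assay, with a stated time of 72 h (on this read-out higher numbers stand for lower toxicity in this test and lower numbers for higher toxicity in this test), compound 2 gives 218000 nM, the lowest of the two numbers in hand, while compound 1 gives 465000 nM. For the measured compounds named here, the one measured step, a 2.1-fold lower number from compound 1 to compound 2 (0.33 log units; beyond the scatter), runs by chloro in place of hydrogen on an aromatic carbon and ends at compound 2.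

Compound 3 `CCOC(=O)c1[nH]c(=O)c(C#N)cc1C(=O)c1ccc(C)cc1` is not yet measured. It differs from compound 2 by methyl in place of chloro on an aromatic carbon. Going by the values given here, no measured step exchanges methyl for chloro, so only the single step from compound 1 to compound 2 is of any use, and it shows that a change at this aromatic carbon moved the number by a modest amount, just beyond the scatter. Compound 3 carries a substituent at that carbon as compound 2 does, so the expected step of a 1.4-fold higher number from compound 2 to compound 3 (0.14 log units; within the scatter) from compound 2 to compound 3 is small and, if anything, toward the number of compound 1. For compound 3 the estimated value in this assay is 300000 nM, with a range from 150000 nM to 600000 nM.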

Compound 3, half-maximal cytotoxic concentration: 512000 nM
Compound 3: the middle estimate sits 1.7-fold (0.23 log units) below what was measured; the measured number falls inside the stated range.
By their numbers in this assay, from the lowest: compound 2; then compounds 1 and 3 (each within the scatter of the next).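

Methyl in place of chloro at this aromatic carbon, para to a large group, gives a 2.3-fold higher number from compound 2 to compound 3 (0.37 log units; beyond the scatter) in this assay, so what matters here is which group sits on this carbon and not merely that hydrogen has been replaced. Methyl in place of hydrogen gives a 1.1-fold higher number from compound 1 to compound 3 (0.04 log units; within the scatter), so compound 3 cannot be told apart from compound 1 in this test, and among the three groups seen at this carbon, only the chloro of compound 2 stands beyond the scatter of both others. Nothing at hand bears on why chloro stands apart from methyl and hydrogen.

As far as these compounds go, whether the lower number of compound 2 is special to chloro or is shared by fluoro or bromo remains open, as does whether an amine, a carboxylic acid or a longer chain on this carbon would read like compound 2 or like compound 1 and compound 3. Also open, from the compounds shown here alone, is whether the gap between chloro and methyl would persist with the ethyl ester or the nitrile of the shared core replaced, for example with a carboxylic acid in place of the ester.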